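Replacing the Trimethoxyphenyl Amide of Compound 2

The source may report more compounds than this note shows. Statements on the series, on what has been measured and on what is new or still open speak of the compounds shown alone.

Compound 2 `COc1cc(C(=O)NC2=C(C#N)C(c3ccc(Cl)cc3Cl)C3=C(CCCC3=O)N2c2ccc(S(N)(=O)=O)cc2)cc(OC)c1OC` stands at the top of the two numbers measured in a functional assay on Ehrlich cells (Mus musculus) for cytotoxicity, read by trypan blue exclusion, with a stated time of 2 h, tested at 100 ug/mL; a higher number here means a stronger effect of the compound at the concentration tested, a lower number a weaker effect: compound 2 gives 95%. Its nearest neighbour is compound 1 `N#CC1=C(NC(=O)/C=C/c2ccccc2)N(c2ccc(S(N)(=O)=O)cc2)C2=C(C(=O)CCC2)C1c1ccc(Cl)cc1Cl`, which in this assay gives 45%; the step of a number 50 percentage points higher from compound 1 to compound 2 (beyond the scatter) came with 3,4,5-trimethoxyphenyl in place of 2-phenylethenyl on a carbonyl carbon. Compound 3 `CC(=O)CC(=O)NC1=C(C#N)C(c2ccc(Cl)cc2Cl)C2=C(CCCC2=O)N1c1ccc(S(N)(=O)=O)cc1` is not yet measured; it differs from compound 2 as follows: 2-oxopropyl in place of 3,4,5-trimethoxyphenyl on a carbonyl carbon. Within the data shown here, only one measured step touches this carbonyl carbon, and it was large, a number 50 percentage points higher from compound 1 to compound 2 (beyond the scatter), when the 3,4,5-trimethoxyphenyl entered; here that group leaves again and a 2-oxopropyl enters, a group no measured compound carries, so the direction rests on a single step. The expected step of a number 45 percentage points lower from compound 2 to compound 3 (beyond the scatter) is downward, beyond the scatter. Compound 3 is therefore estimated at 50% in this assay, with a range from 25% to 85%.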

Compound 3, a percentage reported as activity, at one concentration (the size of the read-out at that concentration, not a potency): 80%
Compound 3: the middle estimate sits 30 percentage points below what was measured; low and high end bracket the measured number.
By their numbers in this assay, from the lowest: compound 1; then compound 3; then compound 2.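

In this assay, an aromatic ring on this carbonyl carbon proves not to be needed for a high number: a number 15 percentage points lower from compound 2 to compound 3 (beyond the scatter), although the 2-oxopropyl group has no ring and fewer heavy atoms than the 3,4,5-trimethoxyphenyl group. The same replacement stands well clear of the 2-phenylethenyl group, a number 35 percentage points higher from compound 1 to compound 3 (beyond the scatter), so a ring alone does not order the three compounds: compound 1 carries one and gives the lowest number, while compound 3 carries none and lies above it. No measurement at hand bears on why these compounds differ.

On these data alone, whether a plain methyl, a longer alkyl chain or a carboxylic acid on this carbonyl carbon would keep the number near that of compound 3 remains open, as does the role of the ketone carbonyl within the 2-oxopropyl group. All three values come from a single concentration, so they speak only of a stronger or weaker effect at that concentration.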